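Amide variation on the shared core, next step

The source may report more compounds than this note shows. Statements on the series, on what has been measured and on what is new or still open speak of the compounds shown alone.

Measured so far:
compound 1 `COc1cc(/C=C/C(=O)c2cccc(NC(=O)c3c(Cl)cccc3Cl)c2)ccc1O` — 99%
compound 2 `COc1cc(/C=C/C(=O)c2cccc(NC(=O)c3ccc(Cl)cc3)c2)ccc1O` — 66%

Within the data shown here, in a functional assay on HUVEC cells (Homo sapiens) for inhibition, tested at 10 ug/mL (a higher number here means a stronger effect of the compound at the concentration tested, a lower number a weaker effect), compound 1 gives 99% and compound 2 gives 66%; compound 2 thus stands lowest of the two numbers, with compound 1 as its nearest neighbour, and the single measured step, a number 33 percentage points lower from compound 1 to compound 2 (beyond the scatter), lies beyond the scatter.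

Compound 3 `COC(=O)C(=O)Nc1cccc(C(=O)/C=C/c2ccc(O)c(OC)c2)c1` is not yet measured. Against compound 2 it shows (methoxycarbonyl in place of 4-chlorophenyl on a carbonyl carbon). Among the measured compounds shown here, no measured step covers this exact change; the step of a number 33 percentage points lower from compound 1 to compound 2 (beyond the scatter) bears on it only in showing that altering the group on this carbonyl carbon moves the read-out by a large amount, and the present change removes the aromatic ring from that position altogether. A further fall is therefore expected, its size uncertain. Compound 3 is estimated at 45%, range 10% to 85%, the expected step being a number 21 percentage points lower from compound 2 to compound 3 (beyond the scatter).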

Compound 3, a percentage reported as inhibition, at one concentration (the size of the read-out at that concentration, not a potency): 43%
Estimate against measurement, compound 3: 2 percentage points above; measured number inside the range.
By their numbers in this assay, from the lowest: compound 3; then compound 2; then compound 1.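

Working notes on the amide group: in this assay, the earlier pair compared only two chlorinated phenyl groups on this carbonyl carbon, whereas methoxycarbonyl now puts a group without a ring there. That change gives a number 23 percentage points lower from compound 2 to compound 3 (beyond the scatter) and, against the dichlorinated group, a number 56 percentage points lower from compound 1 to compound 3 (beyond the scatter). Among these three compounds, both chlorinated phenyl groups therefore stand above methoxycarbonyl, while compound 3 still retains a clear read-out without a ring at this position. No available evidence accounts for these differences.

With only one ringless group shown, the effect of losing the ring cannot be separated from the effect of methoxycarbonyl itself. As far as these compounds go, the response to a carboxylic acid, an amine or a longer alkyl chain on this carbonyl carbon remains open, as does that to an unsubstituted phenyl group.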